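Homologating the selenium-bearing side chain in a quinone ester series

The source may hold more compounds than are shown below. What is called first, only, known or untested is meant among the compounds shown, and "the series" means these compounds.

Measured so far:
- compound 1, `CC1=C(SCCC(=O)OC(C[Se]c2ccccc2)C(=O)NCCCCCC(=O)OCc2ccccc2)C(=O)c2ccccc2C1=O`: 23000 nM
- compound 2, `CC1=C(SCCC(=O)OC(C[Se]C2=C(C)C(=O)c3ccccc3C2=O)C(=O)NC(C)(C)C)C(=O)c2ccccc2C1=O`: 1000 nM
- compound 3, `CC1=C(SCCC(=O)OC(C[Se]C2=C(C)C(=O)c3ccccc3C2=O)C(=O)NCCCCCC(=O)OCc2ccccc2)C(=O)c2ccccc2C1=O`: 7000 nM

Of the compounds shown here, three sharing one quinone-based core have been tested in an ADME assay on HUVEC cells (Homo sapiens) for cytotoxicity, read by MTT assay, with a stated time of 24 h; a lower number here means a stronger inhibitor, a higher number a weaker inhibitor. Compound 1 gives 23000 nM in this assay, the highest of the three numbers, and so the weakest inhibitor among them. Its nearest neighbour is compound 3, at 7000 nM, a gap that lies beyond the usual scatter; compound 2, at 1000 nM, lies furthest away, also beyond the scatter. Both of these partners carry a second copy of the quinone core on the selenium, whereas compound 1 carries a plain phenyl there, so no single-point comparison with compound 1 is available.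

Compound 4, `CC1=C(SCCC(=O)OC(CC[Se]c2ccccc2)C(=O)NCCCCCC(=O)OCc2ccccc2)C(=O)c2ccccc2C1=O`, has not yet been measured. It differs from compound 1 in one place: a group of 8 heavy atoms (7 carbon, 1 selenium; one six-membered aromatic ring of carbon only) in place of a group of 7 heavy atoms (6 carbon, 1 selenium; one six-membered aromatic ring of carbon only), on a saturated chain carbon, two bonds along the chain from a carbonyl carbon and an oxygen next to a carbonyl group. In plain terms, the chain between the ester-bearing carbon and the selenium is one carbon longer, with everything else kept.

Going by the values given here, with no measured step of this kind to lean on, a lengthening by a single chain carbon is expected to move this assay little, and in no firm direction; the expected step is a 1.2-fold lower number from compound 1 to compound 4 (0.06 log units; within the scatter), within the scatter. Compound 4 is therefore estimated at 20000 nM, with a range from 7000 nM to 60000 nM.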

Compound 4, half-maximal inhibitory concentration: 17000 nM
Compound 4: middle estimate off by 1.2-fold (0.07 log units), on the high side, within the range that was stated.
By their numbers in this assay, from the lowest: compound 2; then compound 3; then compounds 4 and 1 (each within the scatter of the next).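

In this assay, the group of 8 heavy atoms in place of the group of 7 heavy atoms, on a saturated chain carbon, gives a 1.4-fold lower number from compound 1 to compound 4 (0.13 log units; within the scatter), so the two compounds cannot be told apart. Going by these compounds alone, this is the first comparison in which only one place changes, and it shows that this position, with a phenyl group on the selenium, tolerates this lengthening of the chain without a change that can be read beyond the scatter. No measurement of any property of these groups accompanies this result, and the data give no explanation for it.

Going by these compounds, this is a single pair, so it sets no trend, and it remains open whether the same lengthening would also leave the number unmoved when the selenium carries a second copy of the shared core, as in compound 3. On these data alone, it also remains open whether a still longer chain at this position, or an amine or a carboxylic acid placed on it, would shift the number beyond the scatter.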